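The source may report more compounds than this note shows. Statements on the series, on what has been measured and on what is new or still open speak of the compounds shown alone.

In an assay on MDA-MB-231 cells for binding affinity to C-X-C chemokine receptor type 4 (Homo sapiens), read by immunofluorescence and microscopy, with stated times of 10 min and 30 min (on this read-out higher numbers stand for an effect only at larger amounts of compound and lower numbers for an effect already at smaller amounts), compound 3 `O=C(NCc1ccc(CNS(=O)(=O)c2ccccc2)cc1)c1ccc([N+](=O)[O-])cc1` gives 100 nM, the highest number of the three measured compounds: compound 1 `Cc1ccc(S(=O)(=O)NCc2ccc(CNC(=O)c3ccc([N+](=O)[O-])cc3)cc2)cc1` gives 10 nM and compound 2 `COc1ccccc1C(=O)NCc1ccc(CNS(=O)(=O)c2ccccc2)cc1` gives 1 nM. Compound 4 `O=C(NCc1ccc(CNS(=O)(=O)c2ccccc2)cc1)c1ccccc1Cl` differs from compound 3 in one place: 2-chlorophenyl in place of 4-nitrophenyl on a carbonyl carbon. The step that bears on this change is a 100-fold higher number from compound 2 to compound 3 (2.00 log units; beyond the scatter), in which a 2-methoxyphenyl group was exchanged for the 4-nitrophenyl that now leaves. Compound 4 instead carries a 2-chlorophenyl group, a closer relative of the group in compound 2, so a large fall in the number is expected in this assay. The step of a 10-fold higher number from compound 1 to compound 3 (1.00 log units; beyond the scatter) concerns another part of the molecule and adds little here. Compound 4 is therefore expected to give 3 nM (range 1 nM to 30 nM), a step of a 33-fold lower number from compound 3 to compound 4 (1.52 log units; beyond the scatter).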

Compound 4, effective concentration (reported as EC, without a stated level of effect): 10 nM
Compound 4: middle estimate off by 3.3-fold (0.52 log units), on the low side; the range from low to high includes it.
By their numbers in this assay, from the lowest: compound 2; then compounds 1 and 4 (each within the scatter of the next); then compound 3.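

In this assay, 2-chlorophenyl in place of 4-nitrophenyl on the carbonyl carbon lowers the number (a 10-fold lower number from compound 3 to compound 4 (1.00 log units; beyond the scatter)), so the fall is not confined to the 2-methoxyphenyl group of compound 2. The two groups are not interchangeable, however: chloro in place of methoxy raises the number (a 10-fold higher number from compound 2 to compound 4 (1.00 log units; beyond the scatter)). No measurement here accounts for either step. The compounds shown do not separate the effect of the group's identity from that of its ring position. Going by these compounds, how a phenyl ring bearing an amine or a carboxylic acid would behave on this carbonyl carbon also remains open.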